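A few compounds are considered here, and "the series" means these few. Any claim that something is new, unique, unknown or untested is made for them only; others in the source may bear on it.

In a functional assay on CCRF-CEM cells (Homo sapiens) for inhibition, read by MTT assay, with a stated time of 72 h (a lower number here means a stronger inhibitor, a higher number a weaker inhibitor), compound 1 `COc1cc(NC(C)CCCNC(=O)Nc2ccc(Br)cc2)c2ncccc2c1` gives 23000 nM as its half-maximal inhibitory concentration. Within the data shown here, the one other compound measured so far is compound 2 `COc1cc(NC(C)CCCNC(=O)NNC(=O)Nc2ccc(C(F)(F)F)cc2)c2ncccc2c1` with 18000 nM on the same read-out. These two values lie within the usual scatter of each other, so compound 1 sits level with compound 2. The change to compound 3 `COc1cc(NC(C)CCCNC(=O)Nc2ccc(F)cc2)c2ncccc2c1` is small in count, as fluoro in place of bromo on an aromatic carbon shows: fluoro in place of bromo on an aromatic carbon, para to a large group. Among the measured compounds shown here, no measured pair of compounds shows this kind of swap, so the data give no direct guide to its size. No shift beyond the scatter is expected, with only a slight lean towards a weaker compound. The estimated move is a 1.1-fold higher number from compound 1 to compound 3 (0.04 log units; within the scatter) and it stays small. For compound 3 the expected value is 25000 nM with an estimated range from 12000 nM to 50000 nM in this assay once it is measured.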

Compound 3, half-maximal inhibitory concentration: 26000 nM
The estimate for compound 3 lay 1.0-fold (0.02 log units) below the measured number; the measured number falls inside the stated range.
By their numbers in this assay, from the lowest: compounds 2, 1 and 3 (each within the scatter of the next).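

In this assay, fluoro in place of bromo gives a 1.1-fold higher number from compound 1 to compound 3 (0.05 log units; within the scatter), so at this aromatic carbon, para to a large group, this exchange of one halogen for another does not move the number beyond the scatter. Among these compounds, compound 2 differs from compound 1 in more than one place, so this is the first direct reading of a single change at this position. Nothing available explains why the number holds steady.

Going by these compounds, two halogens say little about other kinds of group, so it remains open whether an amine or a carboxylic acid at this position would shift the number beyond the scatter. On these data alone, it is also open whether a longer chain on the shared core would change the number more than this swap does.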